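Thiophene Regioisomer Swap on a Shared Imidazopyrazine Core

The source may hold more compounds than are shown below. What is called first, only, known or untested is meant among the compounds shown, and "the series" means these compounds.

Among the measured compounds shown here, compound 2 `c1cn2cc(-c3ccsc3)nc(-c3ccc4ncn(C5CCCCC5)c4c3)c2n1` gives 22% in a functional assay on K562 cells (Homo sapiens) for inhibition, read by sulforhodamine B assay, with a stated time of 48 h, tested at 10 uM (on this read-out higher numbers stand for more inhibition at the one concentration tested (going by the name of the read-out) and lower numbers for less inhibition), the lowest of the two numbers known, with compound 1 `c1ccc2c(-c3cn4ccnc4c(-c4ccc5ncn(C6CCCCC6)c5c4)n3)cccc2c1` nearest at 30.9%, a step of a number 8.9 percentage points lower from compound 1 to compound 2 (within the scatter). Compound 3 `c1csc(-c2cn3ccnc3c(-c3ccc4ncn(C5CCCCC5)c4c3)n2)c1` differs from compound 2 by thiophen-2-yl in place of thiophen-3-yl on an aromatic carbon. For the measured compounds named here, the only measured step at this position, thiophen-3-yl in place of naphthalen-1-yl, stayed within the scatter, and no measured step addresses the isomer swap itself, so no change beyond the scatter is expected: the estimated step is no change at the digits printed from compound 2 to compound 3 (within the scatter). Compound 3 is therefore expected to give about 22%, in the range 8% to 40%.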

Compound 3, a percentage reported as inhibition, at one concentration (the size of the read-out at that concentration, not a potency): 27%
For compound 3 the middle estimate is 5 percentage points below the measured one; low and high end bracket the measured number.
By their numbers in this assay, from the lowest: compounds 2, 3 and 1 (each within the scatter of the next).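

In this assay the swap of thiophen-3-yl for thiophen-2-yl gives a number 5 percentage points higher from compound 2 to compound 3 (within the scatter) and so does not separate the two thiophene isomers at this position. Replacing naphthalen-1-yl with thiophen-2-yl gives a number 3.9 percentage points lower from compound 1 to compound 3 (within the scatter) and so, like the earlier step to thiophen-3-yl, does not set this thiophene apart from the naphthalene. Nothing available offers an explanation for these steps. The compounds shown leave open whether any group on this aromatic carbon moves the number beyond the scatter. An amine or a carboxylic acid in this place would test that.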